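Adding an isopropyl group to compound 2

The compounds below may be only part of what the source reports. "The series", "measured", "known", "first", "only" and "open" are said of these compounds alone.

Compound 1 `CCC(O)CNc1nc(N)nc2ccn(Cc3ccccn3)c12` gives > 24000 nM (a limit)
Compound 2 `Nc1nc(NCc2ccon2)c2c(ccn2Cc2ccccn2)n1` gives > 24000 nM (a limit)

In an ADME assay on HEK293 cells (Homo sapiens) for cytotoxicity, read by ATP content, with a stated time of 6 h (a lower number here means that less compound is tolerated, a higher number that more compound is tolerated), compound 2 gives > 24000 nM as a limit and not a number. It stands at the limit of > 24000 nM in this assay, at which 2 of the 2 values shown sit, with no number to place it. Compound 3 `CC(C)c1cc(CNc2nc(N)nc3ccn(Cc4ccccn4)c23)no1` differs from compound 2 by isopropyl in place of hydrogen on an aromatic carbon with isopropyl in place of hydrogen on an aromatic carbon. Among the measured compounds shown here, the only measured step that the two limits leave unreadable from compound 1 to compound 2 has no readable size and lies at another place, so it sets no size for this change. No change beyond the scatter is expected, and the estimated step is a step that the limit leaves unreadable from compound 2 to compound 3 in this assay with another limit as the likeliest result. For compound 3 the expected value is 25000 nM within an estimated range from 14000 nM to 50000 nM in this measurement.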

Compound 3, half-maximal cytotoxic concentration: > 24000 nM
Compound 3: no number, only a limit; the forecaster's own chance of this, stated with the estimate: 80%; the middle value lies beyond the limit too.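

In this assay compound 3 gives > 24000 nM, a limit and not a number. Among the compounds shown here, with compound 1 and compound 2 also at limits, no step among the three can be read. The compounds shown leave open at what concentration any of them becomes cytotoxic, and whether isopropyl in place of hydrogen changes that concentration.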